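Compound 4 and the group on the carbonyl carbon

The source may hold more compounds than are shown below. What is called first, only, known or untested is meant among the compounds shown, and "the series" means these compounds.

Compound 1 `O=C(c1cccnc1)N1CCC(C(=O)N2N=CCC2c2ccccc2)CC1` gives 2.6
Compound 2 `CCC(=O)N1CCC(C(=O)N2N=CCC2c2ccccc2)CC1` gives 3.2
Compound 3 `O=C(c1cn[nH]c1)N1CCC(C(=O)N2N=CCC2c2ccccc2)CC1` gives 2.1

These three values come from a physicochemical assay for lipophilicity, read by HPLC, measured as chromatographic lipophilicity, at pH 7.4; on this read-out higher numbers stand for higher lipophilicity and lower numbers for lower lipophilicity. Compound 3 stands lowest of the three, with compound 1 nearest to it and compound 2 furthest away. The next compound is compound 4 `O=C(C1CCCCC1)N1CCC(C(=O)N2N=CCC2c2ccccc2)CC1`, which carries cyclohexyl in place of 1H-pyrazol-4-yl on a carbonyl carbon.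

All three measured steps change the group at this same place. The closest guide is a number 1.10 log units lower from compound 2 to compound 3 (beyond the scatter), a large step that also involves the departure or arrival of 1H-pyrazol-4-yl, with ethyl as the partner. The modest a number 0.50 log units lower from compound 1 to compound 3 (beyond the scatter) and the modest a number 0.60 log units higher from compound 1 to compound 2 (beyond the scatter) place pyridin-3-yl between the other two groups. Going by the values given here, no measured compound carries cyclohexyl, so its difference from ethyl remains unknown.

A large upward step is expected, estimated as a number 1.80 log units higher from compound 3 to compound 4 (beyond the scatter). For compound 4 the estimate is 3.9, with an expected range of 3.4 to 4.4.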

Compound 4, distribution coefficient: 5.4
For compound 4 the middle estimate is 1.50 log units below the measured one; the whole stated range lies below it.
By their numbers in this assay, from the lowest: compound 3; then compound 1; then compound 2; then compound 4.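

In this assay, cyclohexyl on this carbonyl carbon takes the series far beyond the range set by the three earlier groups, with a number 3.30 log units higher from compound 3 to compound 4 (beyond the scatter) and a number 2.80 log units higher from compound 1 to compound 4 (beyond the scatter). Even against ethyl, the other group made only of carbon, the change gives a number 2.20 log units higher from compound 2 to compound 4 (beyond the scatter), which exceeds the widest earlier gap, a number 1.10 log units lower from compound 2 to compound 3 (beyond the scatter), so this position allows a much wider span of values than the earlier compounds showed. Nothing available accounts for the size of these steps.

The compounds shown leave open whether the high value of compound 4 goes with the number of carbons in the group, with its non-aromatic ring, or with the absence of nitrogen. A phenyl group or a piperidin-4-yl group on the same carbonyl carbon would help to separate these possibilities.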